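A few compounds are considered here, and "the series" means these few. Any claim that something is new, unique, unknown or untested is made for them only; others in the source may bear on it.

Measured compounds in an assay on isolated protein for binding affinity to Gonadotropin-releasing hormone receptor (Homo sapiens); on this read-out higher numbers stand for weaker inhibition and lower numbers for stronger inhibition:

Compound 1 `COc1cccc(-c2c(C)n(Cc3ccccc3F)c3nc(C(C)(C)C)c(CN(C)C)n3c2=O)c1` gives 1700 nM.
Compound 2 `COc1cccc(-c2c(C)n(Cc3ccccc3F)c3nc(C(C)(C)C)c(CN(C)Cc4ccccn4)n3c2=O)c1` gives 11 nM.
Compound 3 `COC(=O)C(C)(C)c1nc2n(Cc3ccccc3F)c(C)c(-c3cccc(OC)c3)c(=O)n2c1CN(C)Cc1ccccn1` gives 4.2 nM.

Compound 3 stands at the lowest of the three numbers in this assay, its nearest neighbour being compound 2 and the furthest compound 1. Compound 4 `COC(=O)C(C)(C)c1nc2n(Cc3ccccc3F)c(C)c(-c3cccc(OC)c3)c(=O)n2c1CN(C)Cc1ccccc1O` differs from compound 3 in one place: 2-hydroxyphenyl in place of pyridin-2-yl on a saturated chain carbon bound to an amine nitrogen. Going by the values given here, of the measured steps, only the one at the same place bears on this change: a 150-fold lower number from compound 1 to compound 2 (2.19 log units; beyond the scatter), which shows that what sits on this carbon matters greatly. The step of a 2.6-fold lower number from compound 2 to compound 3 (0.42 log units; beyond the scatter) lies elsewhere and says nothing about the ring on the amine side. Among the compounds with values here, no measured pair shows one aromatic ring traded for another at this position, so whether 2-hydroxyphenyl holds the gain that pyridin-2-yl brought is unknown. A modest move toward higher numbers in this assay is expected for compound 4, with a wide range, giving an estimated 2.9-fold higher number from compound 3 to compound 4 (0.46 log units; beyond the scatter). Compound 4 is therefore expected at 12 nM, between 3 nM and 50 nM.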

Compound 4, inhibition constant: 490 nM
Compound 4: the middle estimate sits 41-fold (1.61 log units) below what was measured, and the stated range ends below it.
By their numbers in this assay, from the lowest: compound 3; then compound 2; then compound 4; then compound 1.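

In this assay, 2-hydroxyphenyl in place of pyridin-2-yl on the saturated chain carbon bound to an amine nitrogen gives a 120-fold higher number from compound 3 to compound 4 (2.07 log units; beyond the scatter). The earlier compounds shown here showed only that pyridin-2-yl at this place counts for much against hydrogen, in a 150-fold lower number from compound 1 to compound 2 (2.19 log units; beyond the scatter); this new step shows that trading one six-membered aromatic ring for another can also be large, so an aromatic ring here does not by itself keep the number low. Nothing measured here accounts for this loss.

The pair cannot tell whether the step follows from the ring nitrogen leaving or from the hydroxyl entering. Plain phenyl would separate these two differences, and pyridin-3-yl or 2-methoxyphenyl at this place remain open as well.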